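This account rests on a few compounds, and the source may have more. Where it says the series, first, only, none or still open, it means among the compounds named here.

Three compounds share one core and differ only in the group attached on an aromatic carbon of a six-membered aromatic ring of carbon only, meta to a trifluoromethyl group. In an assay on CHO cells for antagonist activity at transient receptor potential cation channel subfamily V member 1 (Homo sapiens), read by FLIPR (a higher number here means a weaker inhibitor, a lower number a stronger inhibitor), compound 1 `CC(C(=O)NCc1ccc(C(F)(F)F)cc1N1CCC(c2ccc(F)cc2)CC1)c1ccc(NS(C)(=O)=O)c(F)c1` gives 0.9 nM, and compound 2 `CC(C(=O)NCc1ccc(C(F)(F)F)cc1N1CCC(Cc2ccc(F)cc2)CC1)c1ccc(NS(C)(=O)=O)c(F)c1` gives 0.4 nM. For the measured compounds named here, the one measured step between them, a 2.3-fold lower number from compound 1 to compound 2 (0.35 log units; beyond the scatter), concerns a saturated ring carbon and is modest. Compound 3 `CC(C(=O)NCc1ccc(C(F)(F)F)cc1N1CCN(C2CCCCC2)CC1)c1ccc(NS(C)(=O)=O)c(F)c1` gives 13.8 nM in this assay, the highest number of the three, far from both others.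

Compound 4 `CC(C(=O)NCc1ccc(C(F)(F)F)cc1SCc1ccco1)c1ccc(NS(C)(=O)=O)c(F)c1` carries a different change: ((furan-2-yl)methyl)sulfanyl in place of 4-cyclohexylpiperazin-1-yl on an aromatic carbon. Going by the values given here, no measured step matches this replacement, so the expectation rests only on the spread already seen at this position, where compounds 1, 2 and 3 differ widely. An estimate for compound 4 in this assay is therefore 20 nM, within a broad range from 3 nM to 150 nM, and the expected step of a 1.4-fold higher number from compound 3 to compound 4 (0.16 log units; within the scatter) is not beyond the scatter.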

Compound 4, inhibition constant: 3.2 nM
For compound 4 the middle estimate is 6.3-fold (0.80 log units) above the measured one; the measured number falls inside the stated range.
By their numbers in this assay, from the lowest: compound 2; then compound 1; then compound 4; then compound 3.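

In this assay, the step of a 4.3-fold lower number from compound 3 to compound 4 (0.63 log units; beyond the scatter) shows that this position does not need 4-cyclohexylpiperazin-1-yl: a group with fewer heavy atoms, joined through sulfur and carrying a five-membered aromatic ring, gives a lower number. Even so, compound 4 at 3.2 nM ranks behind compound 1 at 0.9 nM and compound 2 at 0.4 nM, so in this set the new group improves on compound 3 without reaching the two lowest numbers. Nothing available explains this step.

Still open, on these data alone, is whether the sulfur or the furan accounts for the change, which an oxygen link in place of the sulfur or a phenyl ring in place of the furan would help separate. Also open, as far as these compounds go, is how a small amine such as morpholine would fare on this aromatic carbon.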